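Morpholine for Piperidine: An Expected Half-Life

The source may report more compounds than this note shows. Statements on the series, on what has been measured and on what is new or still open speak of the compounds shown alone.

Compound 3 `CC(C)(C)c1cc(NC(=O)[C@@H]2CCCCN2C(=O)N2CCCCC2)no1` has the lowest number of the three measured compounds in an ADME assay (liver) for metabolic stability, with Liver microsome (Homo sapiens) as the target, read by LC-MS, using microsomes and NADPH, tested at 1 uM (on this read-out lower numbers stand for a shorter-lived compound and higher numbers for a longer-lived compound), where compound 3 gives 0.233 h. Its nearest neighbour is compound 1 `CC(C)(C)c1cc(NC(=O)[C@@H]2CCCCN2C2CCOCC2)no1`, which in this assay gives 0.317 h; the step of a 1.4-fold lower number from compound 1 to compound 3 (0.13 log units; within the scatter) lies within the scatter. Furthest away is compound 2 `CC(C)(C)c1cc(NC(=O)[C@@H]2CCCCN2C(=O)CC2CCOCC2)no1`, which in this assay gives 1.83 h; the step of a 7.9-fold lower number from compound 2 to compound 3 (0.90 log units; beyond the scatter) lies beyond the scatter, as does a 5.8-fold higher number from compound 1 to compound 2 (0.76 log units; beyond the scatter).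

Compound 4 `CC(C)(C)c1cc(NC(=O)[C@@H]2CCCCN2C(=O)N2CCOCC2)no1` differs from compound 3 in one place: morpholin-4-yl in place of piperidin-1-yl on a carbonyl carbon. Among the measured compounds shown here, no measured step exchanges exactly these two groups. For the measured compounds named here, the only step that alters the group on that carbonyl carbon is a 7.9-fold lower number from compound 2 to compound 3 (0.90 log units; beyond the scatter), and it concerns a different pair of groups, so it cannot be read across directly. The steps of a 1.4-fold lower number from compound 1 to compound 3 (0.13 log units; within the scatter) and a 5.8-fold higher number from compound 1 to compound 2 (0.76 log units; beyond the scatter) change the group on the ring nitrogen instead. With nothing closer to rest on, compound 4 is expected to show a 1.3-fold higher number from compound 3 to compound 4 (0.11 log units; within the scatter), a step that stays within the scatter. Compound 4 is therefore estimated at 0.3 h, within a range from 0.12 h to 0.75 h.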

Compound 4, half-life: > 2 h
Compound 4 gave a limit, no number; the forecaster's own chance of this, stated with the estimate: 5%; middle value at least 6.6-fold (0.82 log units) from the limit.
By their numbers in this assay, from the lowest: compounds 3 and 1 (each within the scatter of the next); then compound 2. At a limit, above all of these: compound 4.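

In this assay, among the compounds shown here, the group on this carbonyl carbon proves decisive even between two six-membered non-aromatic rings of the same heavy-atom count: morpholin-4-yl, with 2 hetero atoms, in place of piperidin-1-yl, with 1, gives an at least 8.5-fold higher number from compound 3 to compound 4 (0.93 log units; beyond the scatter) and so opens a gap that the earlier steps around compound 3 gave no sign of. The reading for compound 4 is a limit and not a number: the limit of > 2 h in this assay, at which 1 of the 4 values shown sits. The same compound also separates from compound 1, with an at least 6.3-fold higher number from compound 1 to compound 4 (0.79 log units; beyond the scatter) as the step, while its standing against compound 2 stays unsettled, since the step of an at least 1.0-fold higher number from compound 2 to compound 4 (0.03 log units; that floor lies within the scatter) has only a floor to show and that floor lies within the scatter.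

The compounds shown do not tell how far compound 4 lies past its limit, and they do not tell why this exchange has so large an effect. They also leave open whether another ring with a second hetero atom on the same carbonyl carbon, such as thiomorpholin-4-yl or piperazin-1-yl, would behave like morpholin-4-yl.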